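This account rests on a few compounds, and the source may have more. Where it says the series, first, only, none or still open, it means among the compounds named here.

Measured compounds:
- compound 1, `CN(C)c1ccc(C(=O)N2CCCCc3ccccc32)c(Cl)c1`, in an assay on HeLa cells for binding affinity to Vasopressin V2 receptor (Homo sapiens) (on this read-out lower numbers stand for stronger inhibition and higher numbers for weaker inhibition), compound 1 gives 18 nM
- compound 2, `CCNc1ccc(C(=O)N2CCCCc3cc(Cl)ccc32)c(Cl)c1`, compound 2 gives 5 nM
- compound 3, `CCCCNc1ccc(C(=O)N2CCCCc3ccccc32)c(Cl)c1`, compound 3 gives 22 nM

Compound 3 stands at the highest of the three numbers, with compound 1 nearest at a distance that lies within the scatter, and compound 2 furthest, its lower number lying beyond the scatter. Compound 2, however, differs from compound 3 in two places, so its value is only a point of reference and not a step.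

Compound 4, `O=C(c1ccc(N2CCCC2)cc1Cl)N1CCCCc2ccccc21`, has not yet been measured in this assay. It differs from compound 3 by one change: pyrrolidin-1-yl in place of butylamino on an aromatic carbon. Going by the values given here, the one measured step that bears on this position is a 1.2-fold higher number from compound 1 to compound 3 (0.09 log units; within the scatter), which shows that exchanging one amine substituent for another at this aromatic carbon left the number essentially unchanged. Closing the butylamino chain into a pyrrolidin-1-yl ring of the same heavy-atom count is expected to behave in the same way, so no step beyond the scatter is expected in this assay for compound 4; the expected step is a 1.5-fold lower number from compound 3 to compound 4 (0.17 log units; within the scatter). Compound 4 is therefore estimated at 15 nM, within a range from 5 nM to 50 nM.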

Compound 4, half-maximal inhibitory concentration: 9 nM
Compound 4: the middle estimate sits 1.7-fold (0.22 log units) above what was measured; low and high end bracket the measured number.
By their numbers in this assay, from the lowest: compounds 2, 4, 1 and 3 (each within the scatter of the next, the first and the last beyond it).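

Read in this assay, the new result shows that this aromatic carbon, para to a large group and meta to a chloro group, is not wholly indifferent to the amine it carries: a 2.4-fold lower number from compound 3 to compound 4 (0.39 log units; beyond the scatter) lies beyond the scatter, though modestly, while the earlier 1.2-fold higher number from compound 1 to compound 3 (0.09 log units; within the scatter) did not. The two groups exchanged have the same count of 5 heavy atoms, yet butylamino has no ring and 1 hydrogen-bond donor, whereas pyrrolidin-1-yl has a five-membered non-aromatic ring and 0 hydrogen-bond donors, so equal heavy-atom count alone did not keep the number in place, and a 2.0-fold lower number from compound 1 to compound 4 (0.30 log units; within the scatter) remains within the scatter, leaving pyrrolidin-1-yl distinguished from butylamino but not from dimethylamino. No measurement given here explains the step from butylamino to the ring, and the reason for it remains unknown.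

Still open, on these data alone, is whether a six-membered piperidin-1-yl ring, a morpholin-4-yl ring with its added oxygen, or a smaller azetidin-1-yl ring would give numbers like that of the pyrrolidin-1-yl compound. Also open, as far as these compounds go, is whether pyrrolidin-1-yl combined with the extra chloro group on the core of compound 2 would give a lower number still.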